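A pyridine ring in place of the methylphenyl amide

This account rests on a few compounds, and the source may have more. Where it says the series, first, only, none or still open, it means among the compounds named here.

Measured so far:
compound 1, `Cc1cc(Cl)ccc1C(=O)Nc1ccc(S(=O)(=O)Nc2ccccc2)cc1`, 912 nM
compound 2, `O=C(Nc1ccc(S(=O)(=O)Nc2ccccc2Cl)cc1)c1ccc(Cl)cc1Cl`, 1260 nM

Two amides built on a shared core have been tested in a functional assay on HEK293 cells for agonist activity at probable G-protein coupled receptor 27 (Homo sapiens), read by a luciferase reporter and beta-arrestin recruitment, with a stated time of 10 min; on this read-out higher numbers stand for an effect only at larger amounts of compound and lower numbers for an effect already at smaller amounts. Compound 1 gives 912 nM in this assay, and compound 2 gives 1260 nM. These two numbers lie within the usual scatter of each other, so compound 1 cannot be set apart from compound 2 on these data.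

Compound 3 `O=C(Nc1ccc(S(=O)(=O)Nc2ccccc2)cc1)c1ccc(Cl)nc1F` has not yet been measured. It differs from compound 1 in one place: 6-chloro-2-fluoropyridin-3-yl in place of 4-chloro-2-methylphenyl on a carbonyl carbon. For the measured compounds named here, no measured pair shows what this exchange of one ring for another does on this core, so no observed step can be leaned on. Because compound 1 gives 912 nM and compound 2 gives 1260 nM, both in the same region, the expectation is that compound 3 stays near that region. The expected step is a 1.2-fold higher number from compound 1 to compound 3 (0.08 log units; within the scatter), not beyond the scatter. Compound 3 is therefore estimated at 1100 nM, with a range from 400 nM to 3200 nM.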

Compound 3, half-maximal effective concentration: 2290 nM
The estimate for compound 3 lay 2.1-fold (0.32 log units) below the measured number; the range from low to high includes it.
By their numbers in this assay, from the lowest: compounds 1, 2 and 3 (each within the scatter of the next, the first and the last beyond it).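

On the shared core, 6-chloro-2-fluoropyridin-3-yl in place of 4-chloro-2-methylphenyl on a carbonyl carbon gives a 2.5-fold higher number from compound 1 to compound 3 (0.40 log units; beyond the scatter) in this assay, so this position does respond to the ring it carries, though the step is modest. The exchange brings in a ring nitrogen and a fluorine and removes a methyl all at once, so this single pair cannot show which of these changes accounts for the step. No measured information is available to explain the rise in the number.

Going by these compounds, it remains open whether a pyridine ring without the fluorine would stay closer to compound 1. Also open, on these data alone, is what a phenyl ring carrying an amine or a carboxylic acid would do at this position.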